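Compound 4: a new aryl group on a limited record

The compounds below may be only part of what the source reports. "The series", "measured", "known", "first", "only" and "open" are said of these compounds alone.

Measured in an ADME assay on microsomes from liver (Rattus norvegicus) for metabolic stability; on this read-out lower numbers stand for a shorter-lived compound and higher numbers for a longer-lived compound:
- Compound 1 `N#Cc1ccc(-c2nc(NCCNc3ccc([N+](=O)[O-])c(N)n3)ncc2-c2ncc[nH]2)cc1`: > 0.5 h
- Compound 2 `Nc1nc(NCCNc2ncc(-c3ncc[nH]3)c(-c3cc(F)c(F)cc3F)n2)ccc1[N+](=O)[O-]`: > 0.5 h
- Compound 3 `Nc1nc(NCCNc2ncc(-c3ncc[nH]3)c(-c3cc(F)c(Cl)cc3Cl)n2)ccc1[N+](=O)[O-]`: > 0.5 h

Compound 3 gives > 0.5 h, which is a limit and not a number. Every result so far has this form: the limit of > 0.5 h in this assay, at which 3 of the 3 values shown sit. Going to compound 4 `COc1cc(Cl)ccc1-c1nc(NCCNc2ccc([N+](=O)[O-])c(N)n2)ncc1-c1ncc[nH]1` puts 4-chloro-2-methoxyphenyl in place of 2,4-dichloro-5-fluorophenyl on an aromatic carbon.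

The measured steps at this same place are a step that the two limits leave unreadable from compound 1 to compound 2, a step that the two limits leave unreadable from compound 1 to compound 3 and a step that the two limits leave unreadable from compound 2 to compound 3. None has a size that can be carried over, so no step beyond the scatter is expected in this assay, and no direction can be given. The expected change is a step that the limit leaves unreadable from compound 3 to compound 4. The estimate for compound 4 is 0.7 h, with an expected range from 0.35 h to 1.4 h.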

Compound 4, half-life: > 0.5 h
Compound 4: no number, only a limit; the forecaster's own chance of this, stated with the estimate: 75%; the middle value is on the limit's open side.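

Compound 4 gives > 0.5 h in this assay, which is a limit and not a number, so no step linking it to compound 1, compound 2 or compound 3 can be read: the limit of > 0.5 h in this assay, at which 4 of the 4 values shown sit.

From the compounds shown here alone, the actual half-lives of these four compounds, and whether swapping the aryl group changes them at all, remain open.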